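A few compounds are considered here, and "the series" means these few. Any claim that something is new, unique, unknown or untested is made for them only; others in the source may bear on it.

Compound 1 `CN(C)CCCn1c(N)c(-c2nc3ccccc3[nH]2)c2nc(C#N)c(C#N)nc21` gives 10400 nM in a functional assay on A549 cells (Homo sapiens) for antiproliferative activity, read by MTT assay, with a stated time of 48 h; a lower number here means a stronger inhibitor, a higher number a weaker inhibitor. Compound 2 `CCN(CC)CCCn1c(N)c(-c2nc3ccccc3[nH]2)c2nc(C#N)c(C#N)nc21` gives 25300 nM in this assay. Compound 3 `CN(C)CCCCn1c(N)c(-c2nc3ccccc3n2C)c2nc(C#N)c(C#N)nc21` gives 6150 nM in this assay.

Compound 2 differs from compound 1 by diethylamino in place of dimethylamino on a saturated chain carbon, three bonds along the chain from an aromatic nitrogen, and this change made a 2.4-fold higher number from compound 1 to compound 2 (0.39 log units; beyond the scatter). Compound 3 and compound 1 differ in more than one place, so the difference between the two cores is not broken down here; the numbers for compound 3 and compound 1 sit within the scatter of each other, while compound 2 stands further off.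

Compound 4 `CCN(CC)CCCCn1c(N)c(-c2nc3ccccc3n2C)c2nc(C#N)c(C#N)nc21` has not yet been measured in this assay. It differs from compound 3 by diethylamino in place of dimethylamino on a saturated chain carbon, four bonds along the chain from an aromatic nitrogen. This is the same kind of change as that from compound 1 to compound 2, though here it sits four bonds along the chain from the aromatic nitrogen rather than three. A step of about the earlier size is expected, a 2.2-fold higher number from compound 3 to compound 4 (0.34 log units; beyond the scatter), because compound 1 to compound 2 showed a 2.4-fold higher number from compound 1 to compound 2 (0.39 log units; beyond the scatter). Compound 4 is therefore estimated at 13500 nM, expected to fall between 6500 nM and 30000 nM.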

Compound 4, half-maximal inhibitory concentration: 1720 nM
Compound 4: the middle estimate sits 7.8-fold (0.89 log units) above what was measured, outside the stated range (below it).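

In this assay the change from dimethylamino to diethylamino did not carry over from the core of compound 1 to the core of compound 3; on the latter it ran the other way (a 3.6-fold lower number from compound 3 to compound 4 (0.55 log units; beyond the scatter)). Set side by side, the two steps disagree: the same change on two cores in this assay, a 2.4-fold higher number (0.39 log units; beyond the scatter) from compound 1 to compound 2 and a 3.6-fold lower number (0.55 log units; beyond the scatter) from compound 3 to compound 4, 8.7-fold (0.94 log units) apart, beyond the scatter of two such steps. This shows that neither the size nor the direction of the change can be assumed from one core to the other in this series, but the two cores differ in more than one place, so these steps cannot say which difference turns the result around.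

The compounds shown leave open how other amines, such as pyrrolidine or morpholine, would behave on either core. Also open, as far as these compounds go, is whether dipropylamino would extend the step seen on either core.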